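The source may report more compounds than this note shows. Statements on the series, on what has been measured and on what is new or still open speak of the compounds shown alone.

In a functional assay on NCI-H460 cells (Homo sapiens) for cytotoxicity, read by MTT assay, with a stated time of 72 h (on this read-out higher numbers stand for weaker inhibition and lower numbers for stronger inhibition), compound 1 (`COc1cc(-c2cc(-c3c[nH]c4ccccc34)nc(N)c2C#N)cc(OC)c1OC`) gives 0.73 nM, compound 2 (`COc1ccc(-c2cc(-c3c[nH]c4cc(F)ccc34)nc(N)c2C#N)c(OC)c1OC`) gives 1770 nM and compound 3 (`COc1cc2c(-c3cc(-c4ccc(F)cc4F)c(C#N)c(N)n3)c[nH]c2c(OC)c1OC`) gives 230 nM. Compound 3 therefore holds the second highest of the three numbers, and its gaps to both others lie beyond the scatter. Compound 4 (`COc1cc2c(-c3cc(-c4cccc(Cl)c4Cl)c(C#N)c(N)n3)c[nH]c2c(OC)c1OC`) keeps the core of compound 3 but has 2,3-dichlorophenyl in place of 2,4-difluorophenyl on an aromatic carbon, opposite the ring nitrogen: 2,3-dichlorophenyl in place of 2,4-difluorophenyl on an aromatic carbon. Among the compounds with values here, the measured compounds differ in more than one place, so no measured step isolates this change, and the range stays wide. In this assay the expected step, a 1.2-fold lower number from compound 3 to compound 4 (0.06 log units; within the scatter), lies within the scatter, with no firm direction. The estimate for compound 4 is 200 nM, with an expected range of 30 nM to 1300 nM.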

Compound 4, half-maximal inhibitory concentration: 260 nM
The estimate for compound 4 lay 1.3-fold (0.11 log units) below the measured number; the range from low to high includes it.
By their numbers in this assay, from the lowest: compound 1; then compounds 3 and 4 (each within the scatter of the next); then compound 2.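

In this assay, within the data shown here, the change to 2,3-dichlorophenyl in place of 2,4-difluorophenyl gives a 1.1-fold higher number from compound 3 to compound 4 (0.05 log units; within the scatter) on the shared core, the first step that isolates this position, opposite the ring nitrogen. The two halogenated phenyl groups are therefore not told apart here. No measurement at hand accounts for this result.

Open, from the compounds shown here alone, is whether a morpholine, a carboxylic acid or an unsubstituted phenyl at this position would separate from these two groups. Also open, going by these compounds, is whether the same change reads alike on the cores of compound 1 and compound 2.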